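Chloro to Fluoro on the Pyrazole Ring of a Glucagon Antagonist

The source may report more compounds than this note shows. Statements on the series, on what has been measured and on what is new or still open speak of the compounds shown alone.

Measured compounds:
- compound 1, `CCCC(Oc1ccc(-n2cc(Cl)cn2)cc1)c1ccc(C(=O)NCCC(=O)O)cc1`: 6500 nM
- compound 2, `O=C(O)CCNC(=O)c1ccc(C(Oc2ccc(-n3cc(C(F)(F)F)cn3)cc2)C2CCCC2)cc1`: 4000 nM

Of the compounds shown here, two have been measured in a functional assay on cells for antagonist activity at Glucagon receptor (Homo sapiens), read by cAMP accumulation, in the presence of a further agent that is not named here (a lower number here means a stronger inhibitor, a higher number a weaker inhibitor), so far. Compound 1 gives 6500 nM in this assay, the higher of the two numbers, and compound 2 gives 4000 nM. The gap between them lies within the usual scatter of the assay, so the two values cannot be told apart, and neither compound can be called the stronger. Among the measured compounds shown here, no pair of measured compounds differs in just one place, so there is no measured single step to lean on.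

Compound 3, `CCCC(Oc1ccc(-n2cc(F)cn2)cc1)c1ccc(C(=O)NCCC(=O)O)cc1`, has not yet been measured. It differs from compound 1 in one place: fluoro in place of chloro on an aromatic carbon. Both groups are single halogen atoms, and nothing in the two measured values points to a direction for a change of this kind. The step in this assay from compound 1 to compound 3 is therefore expected to be small, most likely none beyond the scatter, with a slight lean toward a higher number. Compound 3 is estimated at 8000 nM, with a range from 3000 nM to 20000 nM, which means an expected step of a 1.2-fold higher number from compound 1 to compound 3 (0.09 log units; within the scatter).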

Compound 3, antagonist equilibrium constant: 10000 nM
Beside the measured number, compound 3's estimate is 1.3-fold (0.10 log units) below it, within the range that was stated.
By their numbers in this assay, from the lowest: compounds 2, 1 and 3 (each within the scatter of the next, the first and the last beyond it).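

Among the compounds shown here, compound 1 and compound 3 give the first comparison here in which only one place changes, so the effect of that change can be read directly in this assay. Going from 4-chloro-1H-pyrazol-1-yl to 4-fluoro-1H-pyrazol-1-yl gives a 1.5-fold higher number from compound 1 to compound 3 (0.19 log units; within the scatter), so on this aromatic carbon of the five-membered ring, two ring bonds from the ring nitrogen, the two halogens cannot be told apart in this assay. For the compounds shown here, this reading rests on a single pair of compounds and covers only this exchange of one halogen for another, on this carbon and with the rest of compound 1 left unchanged.

As far as these compounds go, it remains open whether a group of a different kind on this carbon, such as a nitrile, an amine or a longer carbon chain, would shift the number beyond the scatter, and whether any such group would bring it lower or raise it. No measurement shown here bears on what lies behind the result of the halogen exchange.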